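Sulfonyl in place of isoquinolinylcarbonyl on the long chain

A few compounds are considered here, and "the series" means these few. Any claim that something is new, unique, unknown or untested is made for them only; others in the source may bear on it.

Compound 3 `CCCCCCCCCCCCCCCCCCNC(=O)[C@@H](NC(=O)c1nccc2ccccc12)[C@@H](C)O` gives 136000 nM in a functional assay on SW-620 cells (Homo sapiens) for cytotoxicity, read by MTT assay, with a stated time of 48 h (a higher number here means a weaker inhibitor, a lower number a stronger inhibitor), the highest of the three numbers measured. Compound 1 `CCCCCCCCCCCCNC(=O)[C@@H](NS(=O)(=O)c1ccc(C)cc1)[C@@H](C)O` gives 25600 nM and compound 2 `CCCCCCCCCCCCCCNC(=O)[C@@H](NS(=O)(=O)c1ccc(C)cc1)[C@@H](C)O` gives 15200 nM; these two carry the sulfonyl group that compound 4 `CCCCCCCCCCCCCCCCCCNC(=O)[C@@H](NS(=O)(=O)c1ccc(C)cc1)[C@@H](C)O` also carries. Compound 4 arises from compound 3 by (4-methylphenyl)sulfonyl in place of (isoquinolin-1-yl)carbonyl on an amine nitrogen. Among the measured compounds shown here, no measured step covers this exact exchange. For the measured compounds named here, the only measured step, a 1.7-fold lower number from compound 1 to compound 2 (0.23 log units; within the scatter), concerns chain length and is within the scatter, which suggests chain length alone matters little here. Since the two sulfonyl compounds sit well below compound 3, compound 4 is expected to land near them, at an estimated 20000 nM (range 6000 nM to 70000 nM). The expected step is therefore a 6.8-fold lower number from compound 3 to compound 4 (0.83 log units; beyond the scatter).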

Compound 4, half-maximal inhibitory concentration: 32500 nM
For compound 4 the middle estimate is 1.6-fold (0.21 log units) below the measured one; the range from low to high includes it.
By their numbers in this assay, from the lowest: compounds 2, 1 and 4 (each within the scatter of the next, the first and the last beyond it); then compound 3.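

The exchange on the long chain can now be read directly: in this assay, (4-methylphenyl)sulfonyl in place of (isoquinolin-1-yl)carbonyl on the amine nitrogen gives a 4.2-fold lower number from compound 3 to compound 4 (0.62 log units; beyond the scatter) as its step. Among the sulfonyl compounds, chain length shows no steady trend: the butyl extension gives a 2.1-fold higher number from compound 2 to compound 4 (0.33 log units; beyond the scatter) and stands beyond the scatter, while the hexyl extension gives a 1.3-fold higher number from compound 1 to compound 4 (0.10 log units; within the scatter) and stays within it. No evidence is available to explain these numbers.

Still open, on these data alone, is whether the exchange gives a similar step on shorter chains. As far as these compounds go, how a benzoyl or methylsulfonyl group on that nitrogen would compare also remains unknown.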